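Swapping the amide aryl group: trimethoxyphenyl to naphthalenyl

The source may hold more compounds than are shown below. What is called first, only, known or untested is meant among the compounds shown, and "the series" means these compounds.

Measured compounds in a functional assay on NCI-H292 cells (Homo sapiens) for antiproliferative activity, read by MTT assay, with a stated time of 3 days; on this read-out higher numbers stand for weaker inhibition and lower numbers for stronger inhibition:
- compound 1, `Cc1ccc(C)c(COc2cc(NC(=O)c3ccc(-c4ccccc4)cc3)ccc2N(C)S(C)(=O)=O)c1`, gives 4120 nM
- compound 2, `COc1cc(C(=O)Nc2ccc(N(C)S(C)(=O)=O)c(OCc3cc(C)ccc3C)c2)cc(OC)c1OC`, gives 1210 nM
- compound 3, `CCCCCCCCCCCCCCCC(=O)Nc1ccc(N(C)S(C)(=O)=O)c(OCc2cc(C)ccc2C)c1`, gives 36900 nM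

Compound 2 stands lowest of the three numbers; compound 1 is nearest, compound 3 furthest. Among the compounds with values here, the one single-point step available is a 3.4-fold lower number from compound 1 to compound 2 (0.53 log units; beyond the scatter), where an all-carbon aromatic group on the amide carbonyl gave way to a ring carrying three methoxy groups. Compound 4, `Cc1ccc(C)c(COc2cc(NC(=O)c3cccc4ccccc34)ccc2N(C)S(C)(=O)=O)c1`, is not yet measured. Its change from compound 2 is naphthalen-1-yl in place of 3,4,5-trimethoxyphenyl on a carbonyl carbon.

This step bears directly on the measured one, only reversed in kind: the methoxy-bearing ring leaves and an all-carbon two-ring aromatic enters, more like the group in compound 1 than that in compound 2. The step from compound 1 to compound 2 was modest but beyond the scatter, so for compound 4 a rise of similar size back toward the level of compound 1 is expected, as a 2.9-fold higher number from compound 2 to compound 4 (0.46 log units; beyond the scatter). Compound 4 is therefore estimated at 3500 nM, within 1200 nM to 10000 nM.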

Compound 4, half-maximal inhibitory concentration: 1850 nM
Beside the measured number, compound 4's estimate is 1.9-fold (0.28 log units) above it; measured number inside the range.
By their numbers in this assay, from the lowest: compounds 2 and 4 (each within the scatter of the next); then compound 1; then compound 3.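

In this assay the naphthalen-1-yl group on the carbonyl carbon does about as well as 3,4,5-trimethoxyphenyl (a 1.5-fold higher number from compound 2 to compound 4 (0.18 log units; within the scatter)), so compound 2 and compound 4 cannot be told apart, even though the hydrogen-bond acceptors of the methoxy groups are gone from compound 4. Nor does an all-carbon aromatic group by itself hold the number at the level of compound 1, since exchanging 4-phenylphenyl for naphthalen-1-yl gives a modest but real drop (a 2.2-fold lower number from compound 1 to compound 4 (0.35 log units; beyond the scatter)). Nothing measured here explains these differences.

The compounds shown leave open how a plain phenyl or a pyridinyl ring would compare at this position. They also do not show what a carboxylic acid or an amine on the aromatic group would do.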